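The source may hold more compounds than are shown below. What is called first, only, known or untested is meant among the compounds shown, and "the series" means these compounds.

Measured compounds:
compound 1, `Cc1nc2c(Br)c(Br)c(Br)c(Br)c2n1CCCCC#N`, 110%
compound 2, `N#CCCn1cnc2c(Br)c(Br)c(Br)c(Br)c21`, 72%

In a functional assay on MCF7 cells (Homo sapiens) for cytotoxicity, read by MTT assay, with a stated time of 24 h, tested at 20 uM (a lower number here means a stronger effect, a higher number a weaker effect of the compound at the concentration tested), compound 2 gives 72%, the lower of the two numbers recorded so far. For the measured compounds named here, compound 1 gives 110% in this assay, and that number stands higher than the one for compound 2 by a margin beyond the scatter. Going by the values given here, compounds 1 and 2 differ from each other at more than one place, so no single step is set out between them; their two values show only that compound 2 sits at the lower number.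

Compound 3, `N#CCCCCn1cnc2c(Br)c(Br)c(Br)c(Br)c21`, has not been measured in this assay. It differs from compound 2 at one place: 2-cyanoethyl in place of cyano on a saturated chain carbon, two bonds along the chain from an aromatic nitrogen. Among the compounds with values here, no measured pair isolates this change, so the size of the step in this assay is open. Among its differences from compound 2, compound 1 carries a longer chain. Compound 1 gives 110%, and a modest move upward in this assay seems the more likely direction, though a step within the scatter cannot be excluded.

Compound 3 is expected to give 86% in this assay, with a range from 62% to 110%. The step this implies, estimated from compound 2 to compound 3, is a number 14 percentage points higher from compound 2 to compound 3 (beyond the scatter).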

Compound 3, a percentage reported as activity, at one concentration (the size of the read-out at that concentration, not a potency): 99%
Compound 3: middle estimate off by 13 percentage points, on the low side; the measured number falls inside the stated range.
By their numbers in this assay, from the lowest: compound 2; then compound 3; then compound 1.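

Notes on the series: in this assay, the change of 2-cyanoethyl to 4-cyanobutyl at the nitrogen, with no methyl on the core in either compound, is now isolated, and the step reads a number 27 percentage points higher from compound 2 to compound 3 (beyond the scatter). The methyl group can also be read on its own, with hydrogen in place of methyl on an aromatic carbon on the 4-cyanobutyl chain giving a number 11 percentage points lower from compound 1 to compound 3 (beyond the scatter), so each of the two places that separate compound 1 from compound 2 carries a step beyond the scatter, and in both cases the change to the shorter or less substituted partner is not uniform in direction: extending the chain raises the number, while removing the methyl lowers it. No measured data bear on what lies behind either step.

As far as these compounds go, the methyl step is read only on the 4-cyanobutyl chain, so its size on the 2-cyanoethyl chain stays open. Also open, from the compounds shown here alone, is whether a still longer chain would continue the rise seen in this assay, and whether an amine or a carboxylic acid at the chain end in place of the nitrile would keep the number of compound 2 or compound 3.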